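Swapping a Hydroxypropyl Chain for a Cyclopentyl Ring

The source may hold more compounds than are shown below. What is called first, only, known or untested is meant among the compounds shown, and "the series" means these compounds.

Three compounds sharing one core have been measured in an assay on isolated protein for binding affinity to adenosine receptor A1 (Bos taurus); a lower number here means a stronger inhibitor, a higher number a weaker inhibitor:

Compound 1 `Clc1ccccc1Cn1nnc2c(NC3CCC3)nc(-c3ccccc3)nc21`: 24000000 nM
Compound 2 `OCCCNc1nc(-c2ccccc2)nc2c1nnn2Cc1ccccc1`: 21400000 nM
Compound 3 `OCCNc1nc(-c2ccccc2)nc2c1nnn2Cc1ccccc1F`: 54000000 nM

All three numbers are very high, so none of these compounds is a strong binder. Compound 2 gives the lowest number of the three. Its gap to compound 1 lies within the usual scatter of repeated measurements, so the two cannot be told apart; its gap to compound 3 lies beyond the scatter, so compound 2 does bind measurably better than compound 3.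

Compound 4 `c1ccc(Cn2nnc3c(NC4CCCC4)nc(-c4ccccc4)nc32)cc1` has not yet been measured. It differs from compound 2 at one spot: cyclopentyl in place of 3-hydroxypropyl on a nitrogen on an aromatic ring. Compound 1 carries a carbon ring at the same spot and gives a number within the scatter of compound 2, which is the only hint available; the benzyl groups of compounds 1 and 4 also differ, so the hint is loose. The step of a 1.1-fold lower number from compound 2 to compound 4 (0.03 log units; within the scatter) is therefore expected to stay within the scatter, with no clear direction. For compound 4 the estimate is 20000000 nM, with a range from 7000000 nM to 60000000 nM.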

Compound 4, inhibition constant: 11000000 nM
For compound 4 the middle estimate is 1.8-fold (0.26 log units) above the measured one; measured number inside the range.
By their numbers in this assay, from the lowest: compounds 4, 2 and 1 (each within the scatter of the next, the first and the last beyond it); then compound 3.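

Among the compounds shown here, this is the first comparison that changes only the group on this nitrogen, since compounds 1, 2 and 3 also differ in their benzyl groups. In this assay, putting cyclopentyl in place of 3-hydroxypropyl gives a 1.9-fold lower number from compound 2 to compound 4 (0.29 log units; within the scatter), so an open chain with one hydrogen-bond donor and one hydrogen-bond acceptor and a carbon-only ring with neither cannot be told apart at this position. The hydroxyl-bearing chain therefore shows no measurable advantage over the ring here, although no other information is available to explain this result.

The compounds shown leave open whether any group on this nitrogen can move the number beyond the scatter, for example a chain ending in an amine or a carboxylic acid, a longer chain or a six-membered carbon ring. They also leave open whether the same swap would stay within the scatter on a compound with a different benzyl group, and a one-place comparison with a halogen-bearing benzyl group would be needed to settle that.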